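The compounds below may be only part of what the source reports. "The series", "measured", "known", "first", "only" and "open" are said of these compounds alone.

Working notes on the series.

Compound 1, `N#CC1(NC(=O)[C@@H](CC(=O)N2CCOCC2)CC2CCCCC2)CC1`, is the reference point. In an assay on isolated protein for inhibition of cathepsin S (Homo sapiens) (on this read-out higher numbers stand for weaker binding and lower numbers for tighter binding), compound 1 gives 12 nM. Two further compounds carry the same morpholine amide side chain. Compound 3, `CC1CCC(C[C@H](CC(=O)N2CCOCC2)C(=O)N[C@]2(C#N)CCN(C3CCCCC3)C2)CC1`, gives 13.8 nM in this assay; the gap to compound 1 lies within the usual scatter of repeated measurements, so the two cannot be told apart on these numbers. For compound 2, `N#C[C@@]1(NC(=O)[C@@H](CC(=O)N2CCOCC2)CC2CCC(c3ccccc3)CC2)CCN(C2CCCCC2)C1`, the entry in this assay reads "not determined" (no result reported), so nothing can be said about it.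

Compound 4, `CC(C)N1CC[C@@](C#N)(NC(=O)[C@@H](CC(=O)N2CCOCC2)CC2CCCCC2)C1`, has not yet been measured in this assay. It differs from compound 1 in one place: 3-cyano-1-isopropylpyrrolidin-3-yl in place of 1-cyanocyclopropyl on an amide-type nitrogen. Within the data shown here, no pair of measured compounds that differ in only one place is available, so the size of this step cannot be read off directly. Among the measured compounds shown here, the one indirect pointer is compound 3, which also carries a cyano-substituted pyrrolidine on the amide-type nitrogen and gives 13.8 nM, a number within the scatter of compound 1. On that basis no step beyond the scatter is expected in either direction for compound 4. The estimate for compound 4 is 15 nM, with a range from 5 nM to 45 nM; the expected step from compound 1 to compound 4 is a 1.3-fold higher number from compound 1 to compound 4 (0.10 log units; within the scatter).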

Compound 4, dissociation constant: 60.6 nM
Compound 4: the middle estimate sits 4.0-fold (0.61 log units) below what was measured, outside the stated range (above it).
By their numbers in this assay, from the lowest: compounds 1 and 3 (each within the scatter of the next); then compound 4.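

At the amide-type nitrogen the series now has one step that can be read directly: in this assay 3-cyano-1-isopropylpyrrolidin-3-yl in place of 1-cyanocyclopropyl gives a 5.1-fold higher number from compound 1 to compound 4 (0.70 log units; beyond the scatter) and thus weaker binding, a modest step beyond the scatter. The change is not a single feature, as the entering group brings a five-membered non-aromatic ring with 1 hetero atom, an isopropyl group, a defined stereocentre and 2 hydrogen-bond acceptors together, so the step belongs to the exchange as a whole and to no one of these parts. No measurement is at hand that bears on the origin of the step.

Which part of the exchange carries the step stays open, since compound 3 differs from compound 4 in more than one place and gives no clean comparison; 3-cyano-1-methylpyrrolidin-3-yl on the same amide-type nitrogen would test the isopropyl group, and 1-cyanocyclobutyl would test ring size without the ring nitrogen. On these data alone, whether the same step would hold on another side chain, or with the opposite configuration at the new stereocentre, also remains unknown.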